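Methoxy on the benzyl of a piperazine acetamide series

The compounds below may be only part of what the source reports. "The series", "measured", "known", "first", "only" and "open" are said of these compounds alone.

Measured so far in a functional assay on HT-29 cells (Homo sapiens) for cytotoxicity, read by MTT assay, with a stated time of 24 h, tested at 80 ug/mL; a higher number here means a stronger effect of the compound at the concentration tested, a lower number a weaker effect:
Compound 1 `CN(C)/C=C/N1CCN(CC(=O)Nc2ccc(-c3nc(-c4ccccc4)c(-c4ccccc4)n3C)cc2)CC1` gives 45.4%.
Compound 2 `Cn1c(-c2ccc(NC(=O)CN3CCN(c4ccccc4)CC3)cc2)nc(-c2ccccc2)c1-c1ccccc1` gives 63.7%.
Compound 3 `Cn1c(-c2ccc(NC(=O)CN3CCN(Cc4ccccc4)CC3)cc2)nc(-c2ccccc2)c1-c1ccccc1` gives 54.5%.

The three compounds share a core and differ only in the group on an amine nitrogen in a ring. Compound 3 lies between the other two values: a number 9.1 percentage points higher from compound 1 to compound 3 (within the scatter) and a number 9.2 percentage points lower from compound 2 to compound 3 (within the scatter), both within the scatter. For the measured compounds named here, the one step beyond the scatter is a number 18.3 percentage points higher from compound 1 to compound 2 (beyond the scatter).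

Compound 4 `COc1ccc(CN2CCN(CC(=O)Nc3ccc(-c4nc(-c5ccccc5)c(-c5ccccc5)n4C)cc3)CC2)cc1` is the next member. Against compound 3 the change is methoxy in place of hydrogen on an aromatic carbon. Going by the values given here, no measured step touches a substituent on this outer ring; the nearest comparison is a number 9.2 percentage points lower from compound 2 to compound 3 (within the scatter), which kept the value within the scatter, and a number 9.1 percentage points higher from compound 1 to compound 3 (within the scatter) likewise. A methoxy on the outer ring is a smaller change than any of those, so no step beyond the scatter is expected in this assay, in either direction. The expected step is therefore a number 0.5 percentage points higher from compound 3 to compound 4 (within the scatter). For compound 4 the estimate is 55%, with a range from 40% to 70%.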

Compound 4, a percentage reported as activity, at one concentration (the size of the read-out at that concentration, not a potency): 51.2%
Beside the measured number, compound 4's estimate is 3.8 percentage points above it; the range from low to high includes it.
By their numbers in this assay, from the lowest: compounds 1, 4, 3 and 2 (each within the scatter of the next, the first and the last beyond it).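

In this assay, this is the only substituent on the outer ring among the compounds shown: methoxy in place of hydrogen on an aromatic carbon, para to a large group, stays within the scatter (a number 3.3 percentage points lower from compound 3 to compound 4 (within the scatter)), so benzyl and 4-methoxybenzyl cannot be told apart at this position. Against phenyl on the amine nitrogen in a ring, 4-methoxybenzyl gives a step beyond the scatter (a number 12.5 percentage points lower from compound 2 to compound 4 (beyond the scatter)), though a modest one, while the same comparison for benzyl stayed within it; since the two benzyl groups cannot themselves be separated, this is no sign of a real effect of the methoxy, and against 2-(dimethylamino)ethenyl the step remains within the scatter (a number 5.8 percentage points higher from compound 1 to compound 4 (within the scatter)). No available evidence bears on this result.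

Open, from the compounds shown here alone, is whether a group other than methoxy on the same ring, such as a halogen, a hydroxyl, an amine or a carboxylic acid, would move the read-out beyond the scatter. Also open, going by these compounds, is whether a longer chain between the ring nitrogen and the outer ring would do so, and every reading here rests on a single concentration, so none of it speaks to potency.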